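A few compounds are considered here, and "the series" means these few. Any claim that something is new, unique, unknown or untested is made for them only; others in the source may bear on it.

Working notes on the series. Compound 1 `Cc1oc2c3c(ccc2c(=O)c1C)OC[C@H]1[C@@H]3Nc2ccccc2C1(C)C`, compound 2 `Cc1oc2c3c(ccc2c(=O)c1C)OC[C@H]1[C@@H]3Nc2cc3ccccc3cc2C1(C)C` and compound 3 `Cc1ccc2c(c1)C(C)(C)[C@H]1COc3ccc4c(=O)c(C)coc4c3[C@H]1N2` share one core. In a functional assay on MCF7 cells (Homo sapiens) for antiproliferative activity, read by MTT assay (on this read-out higher numbers stand for weaker inhibition and lower numbers for stronger inhibition), compound 1 gives > 100000 nM, which is a limit of the assay and not a number. Compound 2 gives > 100000 nM in this assay, again a limit rather than a measured value. Within the data shown here, compound 3 is the only member with a number, 10200 nM in this assay. Among the measured compounds shown here, compound 2 thus stands at the limit of > 100000 nM in this assay, at which 2 of the 3 values shown sit, and no step between two measured compounds can be read from this set.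

Compound 4 `Cc1coc2c3c(ccc2c1=O)OC[C@H]1[C@@H]3Nc2cc3ccccc3cc2C1(C)C` follows from compound 2 by hydrogen in place of methyl on an aromatic carbon, in words hydrogen in place of methyl on an aromatic carbon, next to the ring oxygen. Compound 3 carries hydrogen at that same place of the core but differs in other parts, so its number in this assay does not fix the size of the change. With compound 2 known only as a limit, the step is expected to be small in this assay, if anything towards stronger inhibition, and it may well stay within the scatter. Compound 4 is expected to give 50000 nM in this assay, with a range from 12000 nM to 200000 nM. The expected step from compound 2 to compound 4 is an at least 2.0-fold lower number from compound 2 to compound 4 (0.30 log units; that floor lies within the scatter) in this assay.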

Compound 4, half-maximal inhibitory concentration: 9000 nM
For compound 4 the middle estimate is 5.6-fold (0.74 log units) above the measured one; measured number outside the range, below it.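

In this assay, among these compounds, hydrogen in place of methyl on an aromatic carbon, next to the ring oxygen, gives an at least 11-fold lower number from compound 2 to compound 4 (1.04 log units; beyond the scatter), the first step that can be read at all. Its size is a floor and not a measured difference: the limit of > 100000 nM in this assay, at which 2 of the 4 values shown sit.

Even so, this single position on the shared core is now shown to matter. Among the compounds shown here, the one change starts from compound 2, which is known only as a limit of the assay. It ends at a number, with compound 4 at 9000 nM in this assay.

The compounds shown leave open how far the step really reaches, and whether the same change would carry a similar step on the core of compound 1, whose value is also only a limit. They also leave open how an ethyl group, a methoxy group, a fluorine atom or a hydroxymethyl group at this place would compare with hydrogen, and what hydrogen in place of the methyl group ortho to this place would do.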